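A few compounds are considered here, and "the series" means these few. Any claim that something is new, unique, unknown or untested is made for them only; others in the source may bear on it.

Of the compounds shown here, two have been measured in a functional assay on HepG2 cells (Homo sapiens) for cytotoxicity, read by MTT assay, with a stated time of 72 h; on this read-out lower numbers stand for stronger inhibition and higher numbers for weaker inhibition. Compound 1 (`O=C(N/N=C/c1ccc(O)cc1)Nc1cc2c(Nc3ccc(F)c(Cl)c3)ncnc2cc1O[C@H]1CCOC1`) gives 70 nM. Compound 2 (`COc1cc2ncnc(Nc3ccc(F)c(Cl)c3)c2cc1NC(=O)N/N=C/c1ccc(OC)c(OC)c1OC`) gives 31200 nM, the higher of the two numbers and so the weaker inhibition, and its gap to compound 1 lies beyond the scatter. These two compounds differ in more than one place, so the gap cannot be assigned to a single change.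

Compound 3 (`COc1cc2ncnc(Nc3ccc(F)c(Cl)c3)c2cc1NC(=O)N/N=C/c1ccc(O)cc1`) has yet to be measured in this assay. It departs from compound 2 in one place: 4-hydroxyphenyl in place of 2,3,4-trimethoxyphenyl on a carbon with a double bond to nitrogen. Compound 1, at 70 nM, carries the same 4-hydroxyphenyl, so a step toward lower numbers, beyond the scatter, is expected in this assay. Compound 3 still differs from compound 1 elsewhere on the core, and the data do not show how much of the gap that part accounts for, so only a partial approach is expected. The estimated step is a 52-fold lower number from compound 2 to compound 3 (1.72 log units; beyond the scatter). For compound 3 the expected value is 600 nM, with an estimated range of 100 nM to 5000 nM.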

Compound 3, half-maximal inhibitory concentration: 26300 nM
For compound 3 the middle estimate is 44-fold (1.64 log units) below the measured one, outside the stated range (above it).
By their numbers in this assay, from the lowest: compound 1; then compounds 3 and 2 (each within the scatter of the next).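

In this assay, the change of the phenyl group alone gives a 1.2-fold lower number from compound 2 to compound 3 (0.07 log units; within the scatter), so with methyl on the oxygen on an aromatic ring, the two phenyl groups are not told apart at this position. The large gap follows the other place instead: with 4-hydroxyphenyl held fixed, methyl in place of oxolan-3-yl on an oxygen on an aromatic ring gives a 380-fold higher number from compound 1 to compound 3 (2.57 log units; beyond the scatter), which ties the low number of compound 1 to the oxolan-3-yl rather than to the 4-hydroxyphenyl alone. No supporting measurement is available to account for the size of either step.

The compounds shown leave open whether 4-hydroxyphenyl and 2,3,4-trimethoxyphenyl would also stay within the scatter of each other with oxolan-3-yl on the oxygen, since that second pairing is absent here. They also leave open how an ethyl group, a longer chain ending in a morpholine, or an oxan-4-yl ring on that oxygen would compare with methyl and oxolan-3-yl, and whether an amine or a carboxylic acid on the phenyl ring would change the picture.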